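From Aminophenyl to Dichlorophenyl: What to Expect for Compound 3

A few compounds are considered here, and "the series" means these few. Any claim that something is new, unique, unknown or untested is made for them only; others in the source may bear on it.

Measured so far:
compound 1, `COc1cc(-c2cc(/C=C/C(=O)c3ccc(N)cc3)[nH]n2)cc(OC)c1OC`, gives 80%.
compound 2, `COc1ccc(-c2cc(/C=C/C(=O)c3ccc(OC)c(OC)c3)[nH]n2)cc1`, gives 77%.

Both numbers come from a functional assay on A549 cells (Homo sapiens) for cytotoxicity, read by sulforhodamine B assay, with a stated time of 48 h, tested at 1 uM; a lower number here means a stronger effect, a higher number a weaker effect of the compound at the concentration tested. Compound 1 has the higher of the two numbers, but compound 2 lies within the usual scatter of it, so the two compounds show much the same, rather weak, effect at this concentration.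

Compound 3, `COc1cc(-c2cc(/C=C/C(=O)c3ccc(Cl)c(Cl)c3)[nH]n2)cc(OC)c1OC`, has not yet been measured. Compared with compound 1 it carries 3,4-dichlorophenyl in place of 4-aminophenyl on a carbonyl carbon. Within the data shown here, no two measured compounds differ in just one place, so there is no measured step to lean on, and the two measured values give no hint of a direction. The step of a number 6 percentage points lower from compound 1 to compound 3 (within the scatter) is therefore expected to be small, most likely inside the scatter, with at most a slight lean toward a stronger effect. Compound 3 is expected to give about 74%, between 52% and 95%.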

Compound 3, a percentage reported as activity, at one concentration (the size of the read-out at that concentration, not a potency): 93%
Compound 3: the middle estimate sits 19 percentage points below what was measured; low and high end bracket the measured number.
By their numbers in this assay, from the lowest: compounds 2 and 1 (each within the scatter of the next); then compound 3.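

In this assay, the change of 4-aminophenyl to 3,4-dichlorophenyl on the carbonyl carbon gives a number 13 percentage points higher from compound 1 to compound 3 (beyond the scatter), which means a weaker effect at the concentration tested. Among these compounds, this is the first comparison in which only one place differs, and it shows that the group at this position can shift the read-out by more than the usual scatter, even with the rest of compound 1 left unchanged. No measurement shown here explains the shift, so this single step records the change without giving its cause.

The compounds shown leave open whether the shift follows the departure of the amine, the arrival of the two chlorines, or both. An unsubstituted phenyl or a phenyl carrying a carboxylic acid at the same place would help separate these possibilities.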